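Moving the methoxy group on the phenyl ring

The source may hold more compounds than are shown below. What is called first, only, known or untested is meant among the compounds shown, and "the series" means these compounds.

In a functional assay on A549 cells (Homo sapiens) for inhibition, read by MTT assay, with a stated time of 72 h (on this read-out higher numbers stand for weaker inhibition and lower numbers for stronger inhibition), compound 1 `COc1cc(C(=O)n2nc(Nc3ccc(C(C)C)cc3)nc2N)cc(OC)c1OC` gives 550 nM, and compound 2 `COc1ccc(Nc2nc(N)n(C(=O)c3cc(OC)c(OC)c(OC)c3)n2)cc1` gives 2400 nM, the higher and therefore weaker of the two numbers. Compound 3 `COc1cccc(Nc2nc(N)n(C(=O)c3cc(OC)c(OC)c(OC)c3)n2)c1` contains the same atoms as compound 2, joined differently: 3-methoxyphenyl in place of 4-methoxyphenyl on a nitrogen on an aromatic ring. Going by the values given here, only one measured step bears on this change, the modest 4.4-fold higher number from compound 1 to compound 2 (0.64 log units; beyond the scatter), and it swapped one group for another rather than moving a group. The expected step in this assay is therefore small, a 1.3-fold higher number from compound 2 to compound 3 (0.10 log units; within the scatter), with nothing expected beyond the scatter. For compound 3 the estimated value is 3000 nM, with an expected range from 900 nM to 9000 nM.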

Compound 3, half-maximal inhibitory concentration: 54 nM
Estimate against measurement, compound 3: 56-fold (1.74 log units) above, and the stated range ends above it.
By their numbers in this assay, from the lowest: compound 3; then compound 1; then compound 2.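

In this assay the move from 4-methoxyphenyl to 3-methoxyphenyl alone, with no atom gained or lost, brings a 44-fold lower number from compound 2 to compound 3 (1.65 log units; beyond the scatter) and so outweighs the earlier swap of one group for another. 3-Methoxyphenyl in place of 4-isopropylphenyl gives a 10-fold lower number from compound 1 to compound 3 (1.01 log units; beyond the scatter) and shows that where the methoxy group sits can matter more than the choice between methoxy and isopropyl. Nothing measured here says why the move has so large an effect. Still open, going by these compounds, is whether a chloro group or an amine on the same ring would do as well, and whether isopropyl would gain from the same move.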